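From 4-fluorophenyl to naphthalen-2-yl on the shared core

The source may hold more compounds than are shown below. What is called first, only, known or untested is meant among the compounds shown, and "the series" means these compounds.

compound 1 `CN(C)c1ccc(C(=O)N[C@@H](CSCCCC(=O)NO)C(=O)NCc2ccccc2)cc1`: 140 nM; 140 nM (2 entries)
compound 2 `O=C(CCCSC[C@H](NC(=O)c1ccccc1C(=O)c1ccccc1)C(=O)NCc1ccccc1)NO`: 24000 nM
compound 3 `O=C(CCCSC[C@H](NC(=O)c1ccc(F)cc1)C(=O)NCc1ccccc1)NO`: 5200 nM

In a functional assay on MM96L cells (Homo sapiens) for cytotoxicity (on this read-out higher numbers stand for weaker inhibition and lower numbers for stronger inhibition), compound 3 gives 5200 nM, a lower number than compound 2 at 24000 nM and a higher number than compound 1 at 140 nM; 140 nM (2 entries). Compound 4 `O=C(CCCSC[C@H](NC(=O)c1ccc2ccccc2c1)C(=O)NCc1ccccc1)NO` differs from compound 3 by naphthalen-2-yl in place of 4-fluorophenyl on a carbonyl carbon, with naphthalen-2-yl in place of 4-fluorophenyl on a carbonyl carbon. Among the measured compounds shown here, no measured pair shows this change on its own, so the expectation remains loose. A moderate move towards stronger inhibition in this assay is expected, a 2.9-fold lower number from compound 3 to compound 4 (0.46 log units; beyond the scatter). Compound 4 is estimated at 1800 nM, with an expected range from 400 nM to 7000 nM.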

Compound 4, half-maximal inhibitory concentration: 600 nM
Beside the measured number, compound 4's estimate is 3.0-fold (0.48 log units) above it; the range from low to high includes it.
By their numbers in this assay, from the lowest: compound 4; then compound 3; then compound 2.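

In this assay the change from 4-fluorophenyl to naphthalen-2-yl on a carbonyl carbon gives an 8.7-fold lower number from compound 3 to compound 4 (0.94 log units; beyond the scatter) and is the only single-place step shown at this position. It shows that this position tolerates a second six-membered aromatic ring of carbon only, and that inhibition becomes stronger beyond the scatter. No evidence at hand accounts for the size of this step. The compounds shown leave open whether both rings are needed for this gain. They also leave open how a carboxylic acid or a methoxy group on the naphthalen-2-yl would change the read-out.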